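From Hydroxy to Fluoro on Compound 2

The source may hold more compounds than are shown below. What is called first, only, known or untested is meant among the compounds shown, and "the series" means these compounds.

Among the measured compounds shown here, in a functional assay on MDA-MB-231 cells (Homo sapiens) for antiproliferative activity, read by sulforhodamine B assay, with a stated time of 48 h (on this read-out lower numbers stand for stronger inhibition and higher numbers for weaker inhibition), compound 1 `COc1cc(OC)c2sc(-c3ccc(N/C=C\C(=O)c4ccc(OC)c(O)c4)cc3)nc2c1` gives 7610 nM and compound 2 `COc1ccc(C(=O)/C=C\Nc2ccc(-c3nc4cc(OC)c(OC)c(OC)c4s3)cc2)cc1O` gives 18100 nM as the higher of the two numbers so far. For the measured compounds named here, the single measured step is a 2.4-fold higher number from compound 1 to compound 2 (0.38 log units; beyond the scatter) and comes from methoxy in place of hydrogen on an aromatic carbon.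

Compound 3 `COc1ccc(C(=O)/C=C\Nc2ccc(-c3nc4cc(OC)c(OC)c(OC)c4s3)cc2)cc1F` differs from compound 2 in one group: fluoro in place of hydroxy on an aromatic carbon with 3-hydroxy-4-methoxyphenyl becoming 3-fluoro-4-methoxyphenyl. The fluoro takes the place of the hydroxy on an aromatic carbon, ortho to a methoxy group.

The measured step bears on this change only loosely, since it leaves the hydroxy untouched. Going by the values given here, no measured pair exchanges hydroxy for fluoro, so the data give no direction. Among the compounds with values here, with a 2.4-fold higher number from compound 1 to compound 2 (0.38 log units; beyond the scatter) as the only guide to scale, a change of similar or smaller size is expected, quite possibly none beyond the scatter. The estimate amounts to a 1.2-fold lower number from compound 2 to compound 3 (0.08 log units; within the scatter) as an expected step with no firm direction. For compound 3 the expected value is 15000 nM within an estimated range of 5000 nM to 40000 nM in this assay when measured.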

Compound 3, half-maximal inhibitory concentration: 16500 nM
Compound 3: middle estimate off by 1.1-fold (0.04 log units), on the low side, within the range that was stated.
By their numbers in this assay, from the lowest: compound 1; then compounds 3 and 2 (each within the scatter of the next).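

In this assay, fluoro in place of hydroxy on this aromatic carbon, ortho to a methoxy group, gives a 1.1-fold lower number from compound 2 to compound 3 (0.04 log units; within the scatter), so compound 2 and compound 3 cannot be told apart on this read-out. Among the compounds shown here, this is the first direct look at this position, as the earlier step concerned a methoxy on the core and left the hydroxy untouched. It shows that, with the rest of compound 2 held fixed, the read-out does not separate hydroxy, counted as 1 hydrogen-bond donor and 1 hydrogen-bond acceptor, from fluoro, counted as 0 of each, and no supporting measurement is available to say what lies behind this result.

The compounds shown leave open whether other groups on this carbon, such as an amine, a chloro group or a carboxylic acid, would also stay within the scatter of compound 2. They also leave open whether the same exchange on the core of compound 1 would give a similarly small step, as this single pair covers only the core of compound 2.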